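Bromo for Methyl on the Aryl Ring of Compound 2

The source may report more compounds than this note shows. Statements on the series, on what has been measured and on what is new or still open speak of the compounds shown alone.

Measured compounds:
compound 1 `COc1ccc(-c2nn(-c3ccccc3)cc2CNc2ccc(F)cc2)cc1` gives 6580 nM
compound 2 `Cc1ccc(-c2nn(-c3ccccc3)cc2CNc2ccc(Br)cc2)cc1` gives 6760 nM

In a functional assay on B16-F10 cells (Mus musculus) for antiproliferative activity, read by MTT assay, with a stated time of 48 h (a higher number here means a weaker inhibitor, a lower number a stronger inhibitor), compound 2 gives 6760 nM and compound 1 gives 6580 nM; the two numbers lie within the scatter of each other, so compound 2 stands level with compound 1 on these two figures. Compound 3 `Brc1ccc(NCc2cn(-c3ccccc3)nc2-c2ccc(Br)cc2)cc1` differs from compound 2 by bromo in place of methyl on an aromatic carbon. Among the compounds with values here, no measured pair shows this change, so its size is unknown from the data; in this assay no step beyond the scatter is expected in either direction. Compound 3 is therefore expected to give about 6500 nM, within 3000 nM to 14000 nM. The expected step is a 1.0-fold lower number from compound 2 to compound 3 (0.02 log units; within the scatter).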

Compound 3, half-maximal inhibitory concentration: 5270 nM
Compound 3: middle estimate off by 1.2-fold (0.09 log units), on the high side; measured number inside the range.
By their numbers in this assay, from the lowest: compounds 3, 1 and 2 (each within the scatter of the next).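

In this assay, within the data shown here, the change from 4-methylphenyl to 4-bromophenyl brings a 1.3-fold lower number from compound 2 to compound 3 (0.11 log units; within the scatter) and gives the first comparison here that differs in one place. At this position, bromo and methyl therefore stand level, which the earlier pair of compounds could not show. No measured evidence on the compounds speaks to why this is so.

From the compounds shown here alone, whether an amine or a carboxylic acid on this carbon would move the number beyond the scatter remains open. So does whether any group at this position can separate these compounds at all.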